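Changing the aryl on the triazole nitrogen in a weak series

The compounds below may be only part of what the source reports. "The series", "measured", "known", "first", "only" and "open" are said of these compounds alone.

Compound 1 `CCc1ccccc1-n1nncc1CN1C(=O)C2(C(C#N)=C(N)Oc3c(N)cc4nc5ccccc5nc4c32)c2ccccc21` gives 22900 nM in an ADME assay on L02 cells (Homo sapiens) for antiproliferative activity, read by MTT assay, with a stated time of 48 h; on this read-out higher numbers stand for weaker inhibition and lower numbers for stronger inhibition.
Compound 2 `Cc1ccc(Cl)cc1-n1nncc1CN1C(=O)C2(C(C#N)=C(N)Oc3c(N)cc4nc5ccccc5nc4c32)c2ccccc21` gives only a limit, > 50000 nM, in this assay.
Compound 3 `Cc1cc(C)c(-n2nncc2CN2C(=O)C3(C(C#N)=C(N)Oc4c(N)cc5nc6ccccc6nc5c43)c3ccccc32)c(C)c1` likewise gives only a limit, > 50000 nM, in this assay.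

Compound 3 therefore stands at the edge of what this assay can report: its value is a limit, not a number, and it shares this position with compound 2, as the limit of > 50000 nM in this assay, at which 2 of the 3 values shown sit, shows. For the measured compounds named here, compound 1 is the only member of the three with a measured number. The two readable steps both run away from compound 1: an at least 2.1-fold higher number from compound 1 to compound 2 (0.33 log units; beyond the scatter) and an at least 2.1-fold higher number from compound 1 to compound 3 (0.33 log units; beyond the scatter). The step between the two limits cannot be sized: a step that the two limits leave unreadable from compound 2 to compound 3.

Compound 4 `COc1cc(-n2nncc2CN2C(=O)C3(C(C#N)=C(N)Oc4c(N)cc5nc6ccccc6nc5c43)c3ccccc32)c(OC)cc1Cl` is compound 3 with 4-chloro-2,5-dimethoxyphenyl in place of 2,4,6-trimethylphenyl on an aromatic nitrogen. Every change made so far at this aromatic nitrogen has moved the number up to the limit, and compound 3 itself already sits there, so the move from compound 3 to compound 4 is expected to bring no readable step: a number no higher from compound 3 to compound 4 (the limit leaves the size open). Compound 4 is thus estimated at 50000 nM in this assay, within 20000 nM to 150000 nM, most likely reported again as a limit.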

Compound 4, half-maximal inhibitory concentration: > 50000 nM
Compound 4 gave a limit, no number; the forecaster's own chance of this, stated with the estimate: 65%; the middle value lies on the limit itself.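

Unlike the 2,4,6-trimethylphenyl it replaces, the 4-chloro-2,5-dimethoxyphenyl group of compound 4 carries 2 hydrogen-bond acceptors, yet in this assay compound 4 still gives only a limit, > 50000 nM. For the compounds shown here, exchanging 2-ethylphenyl for this group gives an at least 2.1-fold higher number from compound 1 to compound 4 (0.33 log units; beyond the scatter), so three differently substituted phenyl groups at this aromatic nitrogen now end without a number, and the one compound that goes against this pattern is compound 1. The steps among compound 2, compound 3 and compound 4 cannot be read, and the series now gathers at a single ceiling: the limit of > 50000 nM in this assay, at which 3 of the 4 values shown sit.

On these data alone, how far compound 2, compound 3 and compound 4 lie past that shared limit remains open, and so does any order among them. Also open, as far as these compounds go, is whether a number returns with a different group at this nitrogen, such as an unsubstituted phenyl, a phenyl bearing an amine or a carboxylic acid, or a longer alkyl chain in place of the aromatic ring.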